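Exchanging the Nitrogen Substituent of Compound 3

A few compounds are considered here, and "the series" means these few. Any claim that something is new, unique, unknown or untested is made for them only; others in the source may bear on it.

In a functional assay on DU-145 cells (Homo sapiens) for cytotoxicity, read by trypan blue exclusion, with a stated time of 96 h (a lower number here means a stronger inhibitor, a higher number a weaker inhibitor), compound 1 `COC(=O)CCNc1cc(CS(=O)(=O)/C=C/c2c(OC)cc(OC)cc2OC)ccc1OC` gives 1500 nM, compound 2 `COC(=O)C(F)(F)Nc1cc(CS(=O)(=O)/C=C/c2c(OC)cc(OC)cc2OC)ccc1OC` gives 250 nM and compound 3 `COC(=O)C(Nc1cc(CS(=O)(=O)/C=C/c2c(OC)cc(OC)cc2OC)ccc1OC)c1ccc(Br)cc1` gives 300 nM. Compound 3 cannot be told apart from compound 2, as a 1.2-fold higher number from compound 2 to compound 3 (0.08 log units; within the scatter) lies within the scatter, while a 5.0-fold lower number from compound 1 to compound 3 (0.70 log units; beyond the scatter) lies beyond it. Compound 4 `COc1cc(OC)c(/C=C/S(=O)(=O)Cc2ccc(OC)c(N[C@@H](C)C(=O)O)c2)c(OC)c1` has not yet been measured. It differs from compound 3 by 1-carboxyethyl in place of (4-bromophenyl)(methoxycarbonyl)methyl on a nitrogen on an aromatic ring. Two modest steps bear on this change, a 6.0-fold lower number from compound 1 to compound 2 (0.78 log units; beyond the scatter) and a 5.0-fold lower number from compound 1 to compound 3 (0.70 log units; beyond the scatter), and both start from the 2-(methoxycarbonyl)ethyl group of compound 1. The two quite different groups of compound 2 and compound 3 give values within the scatter of each other. Among the measured compounds shown here, no measured compound carries a carboxyl group, so that part of the change remains untested. The expected result in this assay is a 1.5-fold lower number from compound 3 to compound 4 (0.18 log units; within the scatter), which would stay within the scatter. Compound 4 is estimated at 200 nM, with an expected range of 50 nM to 1000 nM.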

Compound 4, half-maximal inhibitory concentration: 25 nM
The estimate for compound 4 lay 8.0-fold (0.90 log units) above the measured number; the whole stated range lies above it.
By their numbers in this assay, from the lowest: compound 4; then compounds 2 and 3 (each within the scatter of the next); then compound 1.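

In this assay, a 12-fold lower number from compound 3 to compound 4 (1.08 log units; beyond the scatter) and a 10-fold lower number from compound 2 to compound 4 (1.00 log units; beyond the scatter) show that this nitrogen substituent can take the series to a much lower number, while a 60-fold lower number from compound 1 to compound 4 (1.78 log units; beyond the scatter) makes compound 4 the strongest inhibitor of the four. The step also shows that a low number here does not need the ring of the (4-bromophenyl)(methoxycarbonyl)methyl group, since 1-carboxyethyl has no ring and 5 heavy atoms, fewer than the group it replaces. No measurement shown here accounts for this gain.

Compound 4 differs from the other three in both its carboxylic acid and its branched chain, so the compounds shown cannot say which of the two carries the step. A 1-(methoxycarbonyl)ethyl group, a primary amide or the opposite configuration at the defined stereocentre would each bear on that question, and none stands among them.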